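Triazole-linked flavanones: aryl swap on the benzyl carbon

The source may hold more compounds than are shown below. What is called first, only, known or untested is meant among the compounds shown, and "the series" means these compounds.

Compound 2 `COc1ccc([C@@H]2CC(=O)c3c(O)cc(OCc4cn(Cc5cccc(C#N)c5)nn4)cc3O2)cc1O` stands highest of the two numbers in a functional assay on RAW264.7 cells (Mus musculus) for inhibition, read by Griess assay, with stated times of 2 h and 24 h (on this read-out higher numbers stand for weaker inhibition and lower numbers for stronger inhibition), where compound 2 gives 18000 nM; its nearest neighbour is compound 1 `CCCn1cc(COc2cc(O)c3c(c2)O[C@H](c2ccc(OC)c(O)c2)CC3=O)nn1`, which in this assay gives 9670 nM, a difference within the scatter. Compound 3 `COc1ccc([C@@H]2CC(=O)c3c(O)cc(OCc4cn(Cc5ccccc5C)nn4)cc3O2)cc1O` differs from compound 2 as follows: 2-methylphenyl in place of 3-cyanophenyl on a saturated chain carbon bound to an aromatic nitrogen. Among the measured compounds shown here, the one step that bears on this position, a 1.9-fold higher number from compound 1 to compound 2 (0.27 log units; within the scatter), stayed within the scatter, so a change at the same place is expected to move this assay little, if at all. Compound 3 is therefore estimated at 15000 nM in this assay, with a range of 6000 nM to 40000 nM, a step of a 1.2-fold lower number from compound 2 to compound 3 (0.08 log units; within the scatter).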

Compound 3, half-maximal inhibitory concentration: 13100 nM
Compound 3: middle estimate off by 1.1-fold (0.06 log units), on the high side, within the range that was stated.
By their numbers in this assay, from the lowest: compounds 1, 3 and 2 (each within the scatter of the next).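

In this assay, 2-methylphenyl in place of 3-cyanophenyl gives a 1.4-fold lower number from compound 2 to compound 3 (0.14 log units; within the scatter) and 2-methylphenyl in place of ethyl gives a 1.4-fold higher number from compound 1 to compound 3 (0.13 log units; within the scatter). Three different groups on this saturated chain carbon bound to an aromatic nitrogen therefore stay within the scatter of one another, and the nitrile is not required to keep the number in this range. No measurement shown here accounts for this flat result. As far as these compounds go, whether an amine or a carboxylic acid at this place would give a step beyond the scatter remains open.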